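Methoxy to hydroxy: working notes on compound 4

A few compounds are considered here, and "the series" means these few. Any claim that something is new, unique, unknown or untested is made for them only; others in the source may bear on it.

Measured in a physicochemical assay for solubility, using the shake flask method, in phosphate buffer, with a stated time of 24 h, at pH 7.4; on this read-out higher numbers stand for higher solubility and lower numbers for lower solubility:
- compound 1 `CC(Sc1nc2nn(CC3COC3)cc2c(=O)n1-c1ccccc1)c1ccccc1`: 77000 nM
- compound 2 `COc1cccc(C(C)Sc2nc3c(cnn3C)c(=O)n2-c2ccccc2)c1`: < 2000 nM (a limit of the assay, not a number)
- compound 3 `Cn1ncc2c(=O)n(-c3ccccc3)c(CCc3cccc(F)c3)nc21`: 126000 nM

Compound 2 stands at the limit of < 2000 nM in this assay, at which 1 of the 3 values shown sits; this is a limit, so its true position is not known. Compound 1 gives 77000 nM and compound 3 gives 126000 nM. Within the data shown here, no measured pair in this small set shows the change under consideration, so any step size here is a judgement and not a reading from the series.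

Compound 4 `CC(Sc1nc2c(cnn2C)c(=O)n1-c1ccccc1)c1cccc(O)c1` is compound 2 with hydrogen in place of methyl on an oxygen on an aromatic ring, that is, 3-methoxyphenyl to 3-hydroxyphenyl: hydrogen in place of methyl on an oxygen on an aromatic ring. The rest of the structure stays as it is, so the expectation stays anchored on compound 2 and allows for only a moderate move. A modest upward move in this assay is expected, with the estimated size being an at least 4.0-fold higher number from compound 2 to compound 4 (0.60 log units; beyond the scatter). The result may also come back as a limit again, which would leave the step unsized.

For compound 4 the expected value is 8000 nM, with an estimated range from 2000 nM to 40000 nM.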

Compound 4, solubility: 21000 nM
Compound 4: middle estimate off by 2.6-fold (0.42 log units), on the low side; the measured number falls inside the stated range.
By their numbers in this assay, from the lowest: compound 4; then compounds 1 and 3 (each within the scatter of the next). At a limit, below all of these: compound 2.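

In this assay, among these compounds, hydrogen in place of methyl on an oxygen on an aromatic ring gives an at least 10-fold higher number from compound 2 to compound 4 (1.02 log units; beyond the scatter) with the rest of the structure unchanged, the first step in this small set that can be read for this position. With the methoxy group swapped for hydroxy, compound 4 comes back as a real number, 21000 nM, so the 3-hydroxyphenyl compound can be placed on the scale of the assay. The printed step is only a lower bound on the change, because the starting compound 2 stands at a limit and not at a number: the limit of < 2000 nM in this assay, at which 1 of the 4 values shown sits.

From the compounds shown here alone, how far the step truly reaches stays open, as does whether the higher number is specific to hydroxy or would also appear with an amine or a carboxylic acid in the same place on the aromatic ring. Going by these compounds, compound 1 and compound 3 carry no methoxy group, so whether this change would give a step of similar size elsewhere also remains open.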